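This account rests on a few compounds, and the source may have more. Where it says the series, first, only, none or still open, it means among the compounds named here.

Three compounds sharing one core were tested in a functional assay on MCF7 cells (Homo sapiens) for inhibition, read by MTT assay, with a stated time of 72 h; on this read-out lower numbers stand for stronger inhibition and higher numbers for weaker inhibition. Compound 1 `COc1ccc(Nc2nc(SCc3cn(Cc4ccccc4Cl)nn3)nc(-c3ccccc3)c2C#N)cc1` gives 8050 nM. Compound 2 `Cc1cccc(Nc2nc(SCc3cn(Cc4ccccc4Cl)nn3)nc(-c3ccccc3)c2C#N)c1` gives 19600 nM, with a 2.4-fold higher number from compound 1 to compound 2 (0.39 log units; beyond the scatter). Compound 3 `N#Cc1c(Nc2cccc([N+](=O)[O-])c2)nc(SCc2cn(Cc3ccccc3Cl)nn2)nc1-c1ccccc1` reaches only a limit of the assay, > 64000 nM, not a number. That single reading is the one that sits at the limit of > 64000 nM in this assay, at which 1 of the 3 values shown sits. On the numbers shown, compound 3 therefore stands as the weakest inhibitor of the three, with an at least 7.9-fold higher number from compound 1 to compound 3 (0.90 log units; beyond the scatter) and an at least 3.2-fold higher number from compound 2 to compound 3 (0.51 log units; beyond the scatter).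

Compound 4 `N#Cc1c(Nc2ccccc2F)nc(SCc2cn(Cc3ccccc3Cl)nn2)nc1-c1ccccc1` has not yet been measured. It differs from compound 3 in one place: 2-fluorophenyl in place of 3-nitrophenyl on a nitrogen on an aromatic ring. The two steps that end at compound 3 bear on this change, since both show the 3-nitrophenyl compound beyond the limit while the 4-methoxyphenyl and 3-methylphenyl compounds return numbers. Taking the nitro group away again, as compound 4 does, is expected to bring the number back down, though the starting point being a limit leaves the size uncertain. Compound 4 is estimated at 20000 nM, within a range from 6000 nM to 64000 nM, an expected step of an at least 3.2-fold lower number from compound 3 to compound 4 (0.50 log units; beyond the scatter).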

Compound 4, half-maximal inhibitory concentration: 8060 nM
For compound 4 the middle estimate is 2.5-fold (0.39 log units) above the measured one, within the range that was stated.
By their numbers in this assay, from the lowest: compounds 1 and 4 (each within the scatter of the next); then compound 2. At a limit, above all of these: compound 3.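

In this assay, replacing 3-nitrophenyl with 2-fluorophenyl on this nitrogen gives an at least 7.9-fold lower number from compound 3 to compound 4 (0.89 log units; beyond the scatter). For the compounds shown here, compound 3 stands only at a limit and not at a number, so the true size of that step stays unknown: the limit of > 64000 nM in this assay, at which 1 of the 4 values shown sits. The new result also shows that 4-methoxyphenyl is not the only group here that returns a low number, since the 2-fluorophenyl group cannot be told apart from it, with a 1.0-fold higher number from compound 1 to compound 4 (0.00 log units; within the scatter), and it does better than 3-methylphenyl, with a 2.4-fold lower number from compound 2 to compound 4 (0.39 log units; beyond the scatter).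

Each group on this nitrogen appears with a single substituent in a single place, so the effect of the fluorine cannot be separated from the effect of where it sits. As far as these compounds go, how an unsubstituted phenyl, or a phenyl carrying an amine or a carboxylic acid, would read also remains open.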